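Nitro for chloro on the hydrazone arene of compound 1

The source may report more compounds than this note shows. Statements on the series, on what has been measured and on what is new or still open speak of the compounds shown alone.

Three hydrazones of a shared core have been examined in an ADME assay on HEL cells (Homo sapiens) for cytotoxicity, read by microscopy; a higher number here means that more compound is tolerated, a lower number that less compound is tolerated. Compound 1 `O=C(N/N=C/c1ccc(Cl)cc1)c1cccnc1` gives 29 ug/mL in this assay. Compound 2 `O=C(N/N=C/c1cccc(Br)c1)c1cccnc1` gives 55 ug/mL in this assay, and compound 3 `O=C(N/N=C/c1ccccc1[N+](=O)[O-])c1cccnc1` gives 46 ug/mL in this assay. On paper the number of compound 1 is the lowest of the three, but its gaps to compound 3 and to compound 2 both lie within the usual scatter of repeated measurements, so the three compounds count as alike in how much of each is tolerated.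

Compound 4 `O=C(N/N=C/c1ccc([N+](=O)[O-])cc1)c1cccnc1` has not yet been measured. It differs from compound 1 by one change: nitro in place of chloro on an aromatic carbon. Within the data shown here, no pair of measured compounds shows this particular change, so nothing measured tells how large its effect is. Since the three measured compounds, with chloro, bromo and nitro groups on the same kind of ring, all fall within the scatter of one another, the step from compound 1 to compound 4 in this assay is expected to be small or none beyond the scatter.

Compound 4 is therefore estimated at 40 ug/mL in this assay, with a range from 20 ug/mL to 80 ug/mL, which means an expected step of a 1.4-fold higher number from compound 1 to compound 4 (0.14 log units; within the scatter).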

Compound 4, half-maximal cytotoxic concentration: < 0.16 ug/mL
Compound 4 was reported as a limit (the forecaster's own chance of this, stated with the estimate: 5%); at least 250-fold (2.39 log units) between middle value and limit.
By their numbers in this assay, from the lowest: compounds 1, 3 and 2 (each within the scatter of the next). At a limit, below all of these: compound 4.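

In this assay compound 4 gives < 0.16 ug/mL, which is a limit of the assay and not a number. Nitro in place of chloro on an aromatic carbon, para to a large group, brings an at least 180-fold lower number from compound 1 to compound 4 (2.25 log units; beyond the scatter), and so this position proves far from indifferent to the group it carries, something the alike values of the three earlier compounds gave no sign of. Compound 3, which also carries a nitro group on the same kind of ring, gives 46 ug/mL, so the presence of a nitro group alone does not go with so little being tolerated; the large step belongs to nitro at the place it holds in compound 4.

Going by these compounds, how far the step truly reaches stays open because compound 4 is known only through a limit: the limit of < 0.16 ug/mL in this assay, at which 1 of the 4 values shown sits. Also open is whether another group at this same position, such as an amine, a carboxylic acid or a methoxy group, would stay with compound 1 or fall with compound 4 in this assay.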